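Sulfur-nitrogen group in place of the cyanomethyl chain

The compounds below may be only part of what the source reports. "The series", "measured", "known", "first", "only" and "open" are said of these compounds alone.

Compound 2 `Cc1ccc(=O)n(CCC#N)n1` stands lowest of the two compounds measured in a functional assay on the whole organism (stomach) for inhibition, with Rattus norvegicus as the target, at a dose of 100 mg/kg by the intraduodenal route; on this read-out higher numbers stand for more inhibition at the one dose given (going by the name of the read-out) and lower numbers for less inhibition: compound 2 gives 0.2%. Among the compounds with values here, the only other measured compound, compound 1 `CC/N=C(\S)CCn1nc(-c2ccccc2)ccc1=O`, gives 50.3% in this assay , a number that lies beyond the scatter above compound 2; compound 1 differs from compound 2 in more than one place, so no single-change step can be read from the pair.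

Compound 3 `Cc1ccc(=O)n(CC(=N)S)n1` has not been measured yet. It differs from compound 2 in one place: a group of 3 heavy atoms (1 carbon, 1 nitrogen, 1 sulfur; no ring) in place of a group of 3 heavy atoms (2 carbon, 1 nitrogen; no ring), on a saturated chain carbon bound to an aromatic nitrogen. Within the data shown here, no measured step covers this change. Among the measured compounds shown here, the only pointer is that compound 1, with its reading of 50.3% in this assay , also carries a chain ending in a group that holds nitrogen and sulfur. On that basis the step from compound 2 to compound 3 is expected to be upward and beyond the scatter, a number 24.8 percentage points higher from compound 2 to compound 3 (beyond the scatter). Compound 3 is thus estimated at 25%, with a range from 5% to 55%.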

Compound 3, a percentage reported as inhibition, in the whole organism at one dose (the size of the read-out at that dose, not a potency): 31.5%
Estimate against measurement, compound 3: 6.5 percentage points below; low and high end bracket the measured number.
By their numbers in this assay, from the lowest: compound 2; then compound 3; then compound 1.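

In this assay, the exchange of cyanomethyl for the group of 1 carbon, 1 nitrogen and 1 sulfur, on a saturated chain carbon bound to an aromatic nitrogen, gives a number 31.3 percentage points higher from compound 2 to compound 3 (beyond the scatter). Within the data shown here, this is the first single-place step, and it shows that the read-out responds to this position with the shared core held constant. No measurement of any property bears on this step, so it stands without an explanation.

From the compounds shown here alone, whether the sulfur itself is needed remains open, and the matching amide, with oxygen in place of sulfur, would address that question. Going by these compounds, how an amine or a carboxylic acid would read at this position is also open, as is the effect of a longer chain on the same core.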